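Working notes: carbamoyl to carboxy on compound 2

This account rests on a few compounds, and the source may have more. Where it says the series, first, only, none or still open, it means among the compounds named here.

Measured in an assay on isolated protein for inhibition of 2-Hydroxyacid oxidase 2 (Homo sapiens), tested at 1 uM; a lower number here means a weaker effect, a higher number a stronger effect of the compound at the concentration tested:
compound 1 `Cc1n[nH]c(C(=O)O)c1Cc1cccc(-c2cccc(F)c2)c1` gives 20%
compound 2 `Cc1n[nH]c(C(=O)O)c1Cc1cccc(C(N)=O)c1` gives 8%
compound 3 `Cc1c(Cc2cccc(-c3ccc(F)cc3)c2)c(C(=O)O)nn1C` gives 2%

Compound 2 stands second highest of the three numbers. The step of a number 12 percentage points lower from compound 1 to compound 2 (beyond the scatter) lies beyond the scatter; compound 3, at 2%, sits within the scatter of compound 2, so no order between those two is claimed.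

Compound 4 `Cc1n[nH]c(C(=O)O)c1Cc1cccc(C(=O)O)c1` differs from compound 2 by hydroxy in place of amino on a carbonyl carbon. Going by the values given here, the single measured step, a number 12 percentage points lower from compound 1 to compound 2 (beyond the scatter), exchanges a different group at a different place and does not bear on this change; no measured pair trades hydroxy for amino. With nothing to point either way, the expected step is none beyond the scatter, no change at the digits printed from compound 2 to compound 4 (within the scatter). Compound 4 is therefore estimated at 8%, with a range of -6% to 22%.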

Compound 4, a percentage reported as inhibition, at one concentration (the size of the read-out at that concentration, not a potency): 3%
Compound 4: the middle estimate sits 5 percentage points above what was measured; the range from low to high includes it.
By their numbers in this assay, from the lowest: compounds 3, 4 and 2 (each within the scatter of the next); then compound 1.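

In this assay, hydroxy in place of amino on the carbonyl carbon reads as a number 5 percentage points lower from compound 2 to compound 4 (within the scatter), so this exchange separates carbamoyl from carboxy by no more than the usual scatter. Carboxy in place of 3-fluorophenyl reads as a number 17 percentage points lower from compound 1 to compound 4 (beyond the scatter), which puts a second carbonyl-bearing group beyond the scatter of compound 1, as carbamoyl already was.

Going by these compounds, whether a sulfonamide, an aminomethyl group or an unsubstituted phenyl at this place would read closer to compound 1 stays open. No supporting evidence explains these readings.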